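Thiophene in place of hydroxyphenyl in compound 1

A few compounds are considered here, and "the series" means these few. Any claim that something is new, unique, unknown or untested is made for them only; others in the source may bear on it.

The series shares the core of compound 1 `CC1=CC[C@H](C(C)(C)NC(=S)N/N=C/c2ccc(O)cc2)CC1`, measured in a functional assay on K562 cells (Homo sapiens) for inhibition, read by sulforhodamine B assay, with a stated time of 48 h; on this read-out higher numbers stand for weaker inhibition of growth and lower numbers for stronger inhibition of growth. Compound 1 gives > 100000 nM, which is a limit of the assay and not a number. On the numbers shown, compound 1 therefore stands at the limit, and the limit of > 100000 nM in this assay, at which 1 of the 3 values shown sits, is the only information on it. Among the measured compounds shown here, compound 2 `COc1cc(/C=N/NC(=S)NC(C)(C)[C@H]2CC=C(C)CC2)ccc1O` gives 1900 nM in this assay, and the sole single-place step, an at least 52-fold lower number from compound 1 to compound 2 (1.72 log units; beyond the scatter), is large. Compound 3 `CC1=CC[C@H](C(C)(C)NC(=S)N/N=C/c2cccc([N+](=O)[O-])c2)CC1` gives 45600 nM in this assay; it differs from compound 1 in more than one place, so only its two values can be set beside each other.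

Compound 4 `CC1=CC[C@H](C(C)(C)NC(=S)N/N=C/c2cccs2)CC1` carries thiophen-2-yl in place of 4-hydroxyphenyl on a carbon with a double bond to nitrogen. For the measured compounds named here, no measured step covers this exchange: the step from compound 1 to compound 2 adds a methoxy while the 4-hydroxyphenyl stays, and compound 3 shows that an aromatic ring without the hydroxyl can yield a number, though one far from compound 2. The expectation for compound 4 in this assay is therefore cautious: a step of an at least 2.0-fold lower number from compound 1 to compound 4 (0.30 log units; that floor lies within the scatter) is estimated, toward a number under the limit but still weak. Compound 4 is expected at 50000 nM, with a range from 10000 nM to 200000 nM.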

Compound 4, concentration for 50% growth inhibition: 17600 nM
For compound 4 the middle estimate is 2.8-fold (0.45 log units) above the measured one; measured number inside the range.
By their numbers in this assay, from the lowest: compound 2; then compound 4; then compound 3. At a limit, above all of these: compound 1.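

In this assay, thiophen-2-yl in place of 4-hydroxyphenyl on a carbon with a double bond to nitrogen gives an at least 5.6-fold lower number from compound 1 to compound 4 (0.75 log units; beyond the scatter), so a number under the limit at this place does not require the 4-hydroxyphenyl or its hydrogen-bond donor. The other single-place step, an at least 52-fold lower number from compound 1 to compound 2 (1.72 log units; beyond the scatter), keeps the 4-hydroxyphenyl and adds a methoxy, whereas the new step replaces the whole ring with a five-membered aromatic ring with 1 hetero atom. The true size of the new step stays unknown, and its printed figure is only a floor, because the value of compound 1 is a limit of the assay and not a number: the limit of > 100000 nM in this assay, at which 1 of the 4 values shown sits.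

The compounds shown do not separate the loss of the hydroxyl from the change in ring size, and they do not tell whether a plain phenyl, a furan-2-yl or a pyridin-2-yl would behave like thiophen-2-yl. They also leave open whether a methoxy on the thiophen-2-yl would give a further step of the kind seen with the 4-hydroxyphenyl.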